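Hydroxy in Place of Methoxy on a Pyrazole Urea

The source may report more compounds than this note shows. Statements on the series, on what has been measured and on what is new or still open speak of the compounds shown alone.

Measured so far:
Compound 1 `O=C(Nc1cccc(-n2cc(-c3ccncc3)c(-c3ccc(Cl)c(O)c3)n2)c1)Nc1cccc(C(F)(F)F)c1`: 6510 nM
Compound 2 `COc1cc(-c2nn(-c3cccc(NC(=O)Nc4ccc(Cl)c(C(F)(F)F)c4)c3)cc2-c2ccncc2)ccc1Cl`: 2360 nM

In a functional assay on BT-549 cells (Homo sapiens) for inhibition, read by sulforhodamine B assay, with a stated time of 48 h (on this read-out higher numbers stand for weaker inhibition of growth and lower numbers for stronger inhibition of growth), compound 2 gives 2360 nM, the lowest of the two numbers; compound 1 gives 6510 nM, a higher number that lies beyond the scatter. Going by the values given here, the two compounds differ in more than one place, so their values show only that compound 2 inhibits growth more strongly.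

Compound 3 `O=C(Nc1cccc(-n2cc(-c3ccncc3)c(-c3ccc(Cl)c(O)c3)n2)c1)Nc1ccc(Cl)c(C(F)(F)F)c1` is not yet measured. It differs from compound 2 by hydrogen in place of methyl on an oxygen on an aromatic ring, which brings its phenol into line with that of compound 1 while keeping the urea aryl of compound 2. Among the compounds with values here, no single-change step is known for this change, so the direction is uncertain; the same oxygen substituent appears in the weaker compound 1, but other parts differ too. Compound 3 is expected to give about 3500 nM, with a range of 1500 nM to 8000 nM. The expected step of a 1.5-fold higher number from compound 2 to compound 3 (0.17 log units; within the scatter) is a modest rise that may not exceed the scatter.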

Compound 3, concentration for 50% growth inhibition: 1250 nM
For compound 3 the middle estimate is 2.8-fold (0.45 log units) above the measured one; measured number below the stated range.
By their numbers in this assay, from the lowest: compounds 3 and 2 (each within the scatter of the next); then compound 1.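

In this assay, going by these compounds alone, hydrogen in place of methyl on this oxygen gives the first single-change reading at this position, a 1.9-fold lower number from compound 2 to compound 3 (0.28 log units; within the scatter), so methoxy and hydroxy cannot be told apart here. With the hydroxy held in place, chloro in place of hydrogen on an aromatic carbon gives a 5.2-fold lower number from compound 1 to compound 3 (0.72 log units; beyond the scatter), which shows that the hydroxy shared by compound 1 and compound 3 does not by itself carry a high number. No measurement is at hand that explains the size of either step.

As far as these compounds go, it remains open whether this oxygen position would accept an ethoxy group, or whether an amine or a carboxylic acid could stand in place of the hydroxy. From the compounds shown here alone, it is also open whether the chloro step would be of similar size with methoxy in place of hydroxy.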